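Removing the thiazolyl group from compound 2

This account rests on a few compounds, and the source may have more. Where it says the series, first, only, none or still open, it means among the compounds named here.

Measured in a functional assay on HL-60 cells (Homo sapiens) for antiproliferative activity, read by sulforhodamine B assay, with a stated time of 72 h; a higher number here means a weaker inhibitor, a lower number a stronger inhibitor:
Compound 1 `Clc1ccc(C(/C=C/c2ccccc2)=N\Nc2nncc3ccccc23)cc1`: 7.4 nM
Compound 2 `O=S(=O)(Nc1nccs1)c1ccc(Nc2nncc3ccccc23)cc1`: 77 nM
Compound 3 `O=C1CS/C(=N/Nc2nncc3ccccc23)N1`: 4 nM

Compound 2 has the highest number of the three, and its gaps to compound 1 and compound 3 both lie beyond the usual scatter. Compound 4 `NS(=O)(=O)c1ccc(Nc2nncc3ccccc23)cc1` carries hydrogen in place of 1,3-thiazol-2-yl on a sulfonamide nitrogen. Among the measured compounds shown here, no measured pair shows this change, so the size of the step in this assay is uncertain. Compound 2 at 77 nM sits above the other two, so a small move to a lower number, meaning a somewhat stronger inhibitor, seems likelier than a rise, and it may stay within the scatter. The expected step is a 1.9-fold lower number from compound 2 to compound 4 (0.28 log units; within the scatter). For compound 4 the estimated value is 40 nM, with an expected range of 8 nM to 200 nM.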

Compound 4, half-maximal inhibitory concentration: 18 nM
Beside the measured number, compound 4's estimate is 2.2-fold (0.35 log units) above it, within the range that was stated.
By their numbers in this assay, from the lowest: compounds 3 and 1 (each within the scatter of the next); then compound 4; then compound 2.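

In this assay, among the compounds shown here, replacing 1,3-thiazol-2-yl with hydrogen on the sulfonamide nitrogen gives a 4.3-fold lower number from compound 2 to compound 4 (0.63 log units; beyond the scatter) and so gives the first direct reading of a change at this position. The step is modest but beyond the scatter, which shows that this pair's stronger inhibitor is the one without the five-membered ring. Nothing available explains why the number falls.

From the compounds shown here alone, whether methyl or acetyl on this nitrogen would land nearer compound 4 or compound 2 stays open. So does whether another five-membered aromatic ring would behave like 1,3-thiazol-2-yl.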